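Swapping the Hydrazone Aryl Group on a Shared Core

The compounds below may be only part of what the source reports. "The series", "measured", "known", "first", "only" and "open" are said of these compounds alone.

Compound 1: `CN(C)CCn1cnnc1-c1cc(Oc2ccc(NC(=O)N/N=C/c3c[nH]c4ccccc34)cc2F)ccn1`, 1630 nM in a functional assay on NCI-H460 cells (Homo sapiens) for cytotoxicity, read by MTT assay, with a stated time of 72 h; a lower number here means a stronger inhibitor, a higher number a weaker inhibitor
Compound 2: `COc1ccc(/C=N/NC(=O)Nc2ccc(Oc3ccnc(-c4nncn4CCN(C)C)c3)c(F)c2)c(OC)c1OC`, 1790 nM in this assay

Compound 2 stands at the upper end of the measured numbers, but the step of a 1.1-fold higher number from compound 1 to compound 2 (0.04 log units; within the scatter) is within the scatter, so compound 1 and compound 2 are not separated. Compound 3 `CN(C)CCn1cnnc1-c1cc(Oc2ccc(NC(=O)N/N=C/c3ccccc3O[N+](=O)[O-])cc2F)ccn1` is unmeasured; its change from compound 2 is 2-(nitrooxy)phenyl in place of 2,3,4-trimethoxyphenyl on a carbon with a double bond to nitrogen. Among the compounds with values here, the one step that bears on it, a 1.1-fold higher number from compound 1 to compound 2 (0.04 log units; within the scatter), exchanged the group in the same place without moving the number, so no step beyond the scatter is expected in this assay, and the estimated step is a 1.0-fold higher number from compound 2 to compound 3 (0.00 log units; within the scatter). Compound 3 is therefore expected at 1800 nM, within 700 nM to 4600 nM.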

Compound 3, half-maximal inhibitory concentration: 1270 nM
Beside the measured number, compound 3's estimate is 1.4-fold (0.15 log units) above it, and the stated range covers the measured number.
By their numbers in this assay, from the lowest: compounds 3, 1 and 2 (each within the scatter of the next).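

In this assay, 2-(nitrooxy)phenyl on a carbon with a double bond to nitrogen gives a 1.4-fold lower number from compound 2 to compound 3 (0.15 log units; within the scatter) and a 1.3-fold lower number from compound 1 to compound 3 (0.11 log units; within the scatter). A third, quite different aryl group at this position therefore still leaves all three compounds unseparated, and this group adds a double bond outside aromatic rings without separating them. Nothing measured alongside these numbers accounts for this.

The compounds shown leave open whether a plain phenyl would match the 2-(nitrooxy)phenyl result. They also leave open whether a group without an aromatic ring, such as an alkyl chain, an amine or a carboxylic acid, would step beyond the scatter.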